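The source may report more compounds than this note shows. Statements on the series, on what has been measured and on what is new or still open speak of the compounds shown alone.

Measured so far in a functional assay on UO-31 cells (Homo sapiens) for cytotoxicity, read by sulforhodamine B assay, with a stated time of 48 h; a lower number here means a stronger inhibitor of growth, a higher number a weaker inhibitor of growth:
compound 1 `ClCc1ccc(Cn2cnc3c(Cl)ncnc32)cc1` — 2080 nM
compound 2 `ClCc1ccccc1Cn1cnc2c(Cl)nc(Cl)nc21` — 420 nM

Of the two compounds measured, compound 2 carries the lower number, so it is the stronger growth inhibitor of the pair; compound 1 gives the higher number, and that gap lies beyond the usual scatter. Compound 3 `ClCc1ccccc1Cn1cnc2c(Cl)ncnc21` has not yet been measured. It differs from compound 2 in one place: hydrogen in place of chloro on an aromatic carbon, that is, a chloro group on the shared core is replaced by hydrogen while everything else stays as it is. Among the measured compounds shown here, no measured pair in this set shows the effect of this exact change, so its direction can only be guessed. A modest loss of potency is expected, estimated as a 2.1-fold higher number from compound 2 to compound 3 (0.33 log units; beyond the scatter). For compound 3 the expected value in this assay is therefore 900 nM, with a likely range from 300 nM to 3000 nM.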

Compound 3, concentration for 50% growth inhibition: 2630 nM
For compound 3 the middle estimate is 2.9-fold (0.47 log units) below the measured one; low and high end bracket the measured number.
By their numbers in this assay, from the lowest: compound 2; then compounds 1 and 3 (each within the scatter of the next).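

In this assay, among the compounds shown here, putting hydrogen in place of the chloro group between two ring nitrogen atoms gives a 6.3-fold higher number from compound 2 to compound 3 (0.80 log units; beyond the scatter) and so provides the first direct reading of this change. With everything else held the same, this single chlorine on the shared core clearly matters for growth inhibition, since compound 2 is the better inhibitor of this pair. No available measurement explains this loss.

On these data alone, it remains open whether an amine, a methoxy group or a fluoro group at this position would keep the potency of compound 2 or lose it as hydrogen does. The pair also cannot tell whether this chloro group would matter as much with the chloromethyl group placed as in compound 1.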